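One More Chloro Atom on a Growth Inhibitor

The source may report more compounds than this note shows. Statements on the series, on what has been measured and on what is new or still open speak of the compounds shown alone.

Compound 1 `O=S(=O)(/C=C/c1ccc(Cl)cc1Cl)Cc1ccc(Nc2ncnc3ccccc23)cc1` is tested in a functional assay on OVCAR-8 cells (Homo sapiens) (a lower number here means a stronger inhibitor of growth, a higher number a weaker inhibitor of growth), where compound 1 gives 4000 nM. Compound 2 `O=S(=O)(/C=C/c1ccc(Cl)cc1)Cc1ccc(Nc2ncnc3ccc(Br)cc23)cc1` gives 3000 nM, and compound 3 `O=S(=O)(/C=C/c1ccc(Cl)cc1Cl)Cc1ccc(Nc2ncnc3ccc(Br)cc23)cc1` gives 3000 nM. From compound 1 to compound 3 the bromo step gives a 1.3-fold lower number from compound 1 to compound 3 (0.12 log units; within the scatter). The difference between the cores of compound 1 and compound 2 is not broken down here. From compound 2 to compound 3 the change is chloro in place of hydrogen on an aromatic carbon, and it brings no change at the digits printed from compound 2 to compound 3 (within the scatter). The unmeasured compound 4 `O=S(=O)(/C=C/c1ccc(Cl)cc1Cl)Cc1ccc(Nc2ncnc3cc(Cl)ccc23)cc1` differs from compound 1 by chloro in place of hydrogen on an aromatic carbon. This is the same kind of change, not the same one: in compound 3 the chloro sits ortho to a large group and meta to a chloro group, while in compound 4 it sits on a ring that is part of a fused or bridged system of two rings, meta to a fused ring and para to a fused ring. Resting on no change at the digits printed from compound 2 to compound 3 (within the scatter), the expected step is a 1.1-fold lower number from compound 1 to compound 4 (0.06 log units; within the scatter). Compound 4 is therefore estimated at 3500 nM, expected to fall between 1500 nM and 8000 nM.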

Compound 4, concentration for 50% growth inhibition: > 100000 nM
Compound 4 gave a limit, no number; the forecaster's own chance of this, stated with the estimate: 5%; middle value at least 28-fold (1.45 log units) away from the limit.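

In this assay compound 4 gives > 100000 nM, which is a limit of the assay and not a number. Chloro in place of hydrogen gives an at least 25-fold higher number from compound 1 to compound 4 (1.39 log units; beyond the scatter), so this change cannot simply be carried from one core to another in this series: the same change on two cores in this assay, no change at the digits printed (within the scatter) from compound 2 to compound 3 and an at least 25-fold higher number (1.39 log units; beyond the scatter) from compound 1 to compound 4, at least 25-fold (1.39 log units) apart, beyond the scatter of two such steps. The two chloro groups also sit on different rings, and these compounds alone cannot separate the effect of the place from that of the core.

Going by these compounds, it remains open whether a fluoro or a methoxy group at that place on compound 1 would give a similar step. Also open, on these data alone, is whether chloro at that same place would give a similar step on the core of compound 2.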